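Replacing 2-(methoxycarbonyl)ethenyl with acetyl on a shared core

A few compounds are considered here, and "the series" means these few. Any claim that something is new, unique, unknown or untested is made for them only; others in the source may bear on it.

Measured so far in a functional assay on MCF7 cells (Homo sapiens) for inhibition, read by MTT assay, with a stated time of 72 h (a higher number here means a weaker inhibitor of growth, a lower number a stronger inhibitor of growth), for two compounds:
- compound 1 `CCOC(=O)/C=C/C1=CC[C@H]2C(C)(C)CCC[C@]2(C)[C@H]1C=O` gives 30000 nM
- compound 2 `COC(=O)/C=C/C=C/C1=CC[C@H]2C(C)(C)CCC[C@]2(C)[C@H]1C=O` gives 31000 nM

Compound 2 does not stand apart from compound 1 on these numbers: the measured step is a 1.0-fold higher number from compound 1 to compound 2 (0.01 log units; within the scatter) and so the two are indistinguishable in this test. The next structure is compound 3 `CC(=O)/C=C/C1=CC[C@H]2C(C)(C)CCC[C@]2(C)[C@H]1C=O` and the change leading to it from compound 2 is acetyl in place of 2-(methoxycarbonyl)ethenyl on a double-bonded chain carbon bound to a double-bonded chain carbon with acetyl in place of 2-(methoxycarbonyl)ethenyl on a double-bonded chain carbon bound to a double-bonded chain carbon.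

Among the compounds with values here, only one measured step bears on this change. It is the step between compound 1 and compound 2 at the same place, and it stayed within the scatter. Within the data shown here, that is thin evidence, since no measured compound yet carries acetyl there. Among the measured compounds shown here, still, the one swap seen at this place left the number unmoved, so no clear shift in either direction is expected. The expected step is a 1.1-fold lower number from compound 2 to compound 3 (0.04 log units; within the scatter) and nothing beyond the scatter is anticipated. For compound 3 the estimated value is 28000 nM with an expected range from 12000 nM to 60000 nM in this assay once it is measured.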

Compound 3, concentration for 50% growth inhibition: 20000 nM
Compound 3: the middle estimate sits 1.4-fold (0.15 log units) above what was measured, within the range that was stated.
By their numbers in this assay, from the lowest: compounds 3, 1 and 2 (each within the scatter of the next).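

In this assay the swap to acetyl gives a 1.6-fold lower number from compound 2 to compound 3 (0.19 log units; within the scatter) even though acetyl has 3 heavy atoms where 2-(methoxycarbonyl)ethenyl has 6, so groups of quite different size at this place, on a double-bonded chain carbon bound to a double-bonded chain carbon, cannot be told apart in this test. The second comparison, methyl in place of ethoxy on a carbonyl carbon, gives a 1.5-fold lower number from compound 1 to compound 3 (0.18 log units; within the scatter) and so shows that a carbonyl group carrying methyl and one carrying ethoxy also read alike here. No accompanying measurement is available that could explain these results.

On these data alone, all three compounds keep a carbonyl group on this chain, so it remains open whether a carboxylic acid, an amine or a longer chain at this place would shift the number beyond the scatter. The shared core also stays the same throughout, so these compounds cannot show how much it contributes to the growth inhibition itself.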